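The compounds below may be only part of what the source reports. "The series", "measured", "known", "first", "only" and "open" are said of these compounds alone.

Compound 1, with the structure `Cn1c(=O)c(S(=O)(=O)c2ccc([N+](=O)[O-])cc2F)cc2cnc(Nc3ccc4[nH]ccc4c3)nc21`, gives 200 nM in a functional assay on K562 cells (Homo sapiens) for inhibition, read by trypan blue exclusion, with a stated time of 72 h; a higher number here means a weaker inhibitor, a lower number a stronger inhibitor. Of the two numbers in hand it is the lower one; compound 2, with the structure `Cn1c(=O)c(S(=O)(=O)c2ccc(F)cc2F)cc2cnc(NCc3ccc4[nH]ccc4c3)nc21`, gives 75000 nM in this assay, and the two values stand well apart, beyond the usual scatter. No single change between measured compounds has been traced here, so the step to the new analogue must be judged from the structures alone.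

Compound 3 has the structure `Cn1c(=O)c(S(=O)(=O)c2ccc(F)cc2)cc2cnc(Nc3ccc4[nH]ccc4c3)nc21`. It differs from compound 1 in one place: 4-fluorophenyl in place of 2-fluoro-4-nitrophenyl on a sulfonyl sulfur. The 2-fluoro-4-nitrophenyl group leaves and 4-fluorophenyl enters on the sulfonyl sulfur, with the nitro group and its two acceptors gone.

Compound 3 is expected to give a higher number than compound 1, a modest step of a 3.0-fold higher number from compound 1 to compound 3 (0.48 log units; beyond the scatter), somewhat beyond the scatter. The value of compound 3 in this assay is estimated at 600 nM, within a range from 150 nM to 3000 nM.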

Compound 3, half-maximal inhibitory concentration: 200 nM
Estimate against measurement, compound 3: 3.0-fold (0.48 log units) above, and the stated range covers the measured number.
By their numbers in this assay, from the lowest: compounds 1 and 3 (each within the scatter of the next); then compound 2.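

Going by these compounds alone, exchanging 2-fluoro-4-nitrophenyl for 4-fluorophenyl on the sulfonyl sulfur gives no change at the digits printed from compound 1 to compound 3 (within the scatter) in this assay and this is the first direct reading of this position. With the rest of the structure held constant, the nitro group is not needed to keep the number in this assay, and a group with fewer heavy atoms and no hydrogen-bond acceptors serves equally well here. Nothing measured on these compounds explains why the two groups give matching values.

Going by these compounds, how far this position tolerates change remains open, for example with an amine or a carboxylic acid on the phenyl ring, or a methyl group in place of the ring. Compound 2 differs from compound 1 in more than one place, and the compounds shown do not tell which of those places carries its higher number.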